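The source may hold more compounds than are shown below. What is called first, only, known or untested is meant among the compounds shown, and "the series" means these compounds.

Measured compounds:
Compound 1, `N#Cc1ccc(Cn2cc(C[C@H](O)COCCOC[C@@H](O)Cc3ccc(-c4ccccc4)cc3)nn2)cc1`, gives 8800 nM in a functional assay on HCT-116 cells (Homo sapiens) for inhibition, read by MTT assay, with a stated time of 72 h; on this read-out higher numbers stand for weaker inhibition of growth and lower numbers for stronger inhibition of growth.
Compound 2, `O[C@H](COCCOC[C@@H](O)Cc1cn(-c2cccs2)nn1)Cc1ccc(-c2ccccc2)cc1`, gives 33400 nM in this assay.
Compound 3, `O=c1[nH]c2ccc(-n3cc(C[C@H](O)COCCOC[C@@H](O)Cc4ccc(-c5ccccc5)cc4)nn3)cc2s1`, gives 9200 nM in this assay.

All three share the same core and differ only in the group attached to the aromatic nitrogen. Compound 1 has the lowest number of the three in this assay; compound 3 sits beside it, as the pair shows a 1.0-fold higher number from compound 1 to compound 3 (0.02 log units; within the scatter), while compound 2 lies further off, with a 3.8-fold higher number from compound 1 to compound 2 (0.58 log units; beyond the scatter).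

Compound 4, `O[C@H](COCCOC[C@@H](O)Cc1cn(Cc2cccc(-c3ccccc3)c2)nn1)Cc1ccc(-c2ccccc2)cc1`, has not been measured. It differs from compound 1 in one place: 3-phenylphenyl in place of 4-cyanophenyl on a saturated chain carbon bound to an aromatic nitrogen.

Among the compounds with values here, no measured step changes exactly this part of the molecule. The nearest comparisons are the exchanges at the aromatic nitrogen, where a 3.8-fold higher number from compound 1 to compound 2 (0.58 log units; beyond the scatter) and a 1.0-fold higher number from compound 1 to compound 3 (0.02 log units; within the scatter) show that swapping the group there moves the number only modestly or not beyond the scatter. The change in compound 4 keeps a benzyl-type link and replaces one ring substituent with another, so a small movement is expected, if any. Compound 4 is therefore estimated at 7000 nM, within 2500 nM to 20000 nM, which means an expected step of a 1.3-fold lower number from compound 1 to compound 4 (0.10 log units; within the scatter).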

Compound 4, concentration for 50% growth inhibition: 7200 nM
The estimate for compound 4 lay 1.0-fold (0.01 log units) below the measured number; the range from low to high includes it.
By their numbers in this assay, from the lowest: compounds 4, 1 and 3 (each within the scatter of the next); then compound 2.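

In this assay, the step to a larger group on a saturated chain carbon bound to an aromatic nitrogen gives a 1.2-fold lower number from compound 1 to compound 4 (0.09 log units; within the scatter). The earlier compounds shown here varied the whole group on the aromatic nitrogen, whereas this pair keeps the link through the chain carbon and changes only the aromatic group it carries. Here, 4-cyanophenyl, with a nitrile and 1 hydrogen-bond acceptor, gives way to 3-phenylphenyl, with a second aromatic ring and no hydrogen-bond acceptor, yet the number stays within the scatter; no supporting measurement offers an explanation for this result.

This single exchange alters the substituent and its printed ring position together, so the compounds shown cannot separate the loss of the nitrile from the gain of the extra phenyl ring or from the change of position. They also leave open how the growth-inhibition number would respond if this aromatic group carried something of a different kind, such as an amine or a carboxylic acid, or if it were replaced by a simple longer alkyl chain.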